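The source may report more compounds than this note shows. Statements on the series, on what has been measured and on what is new or still open speak of the compounds shown alone.

Compound 3 `CCCNC(=O)c1ccc2c(ccn2-c2ncc3c(n2)N(C2CCCC2)[C@H](CC)C(=O)N3C)c1` and compound 4 `CCCCNC(=O)c1ccc2c(ccn2-c2ncc3c(n2)N(C2CCCC2)[C@H](CC)C(=O)N3C)c1` share one core, while compound 2 `CCCNS(=O)(=O)c1ccc(Nc2ncc3c(n2)N(c2ccn(C)n2)C(CC)C(=O)N3C)cc1` and compound 1 `CCC1C(=O)N(C)c2cnc(Nc3ccc(S(=O)(=O)NCC(C)C)cc3)nc2N1c1ccn(C)n1` share another; the difference between the two cores is not broken down here. In a functional assay on Huh-7 cells (Homo sapiens) for antiproliferative activity, read by CCK-8 assay, with a stated time of 72 h (on this read-out higher numbers stand for weaker inhibition of growth and lower numbers for stronger inhibition of growth), compound 3 gives 689 nM. Compound 4 differs from compound 3 by methyl in place of hydrogen on a saturated chain carbon, three bonds along the chain from an amide-type nitrogen. The same kind of change appears between compound 2 and compound 1, where it sits on a saturated chain carbon bound to two saturated chain carbons rather than three bonds along the chain from an amide-type nitrogen: methyl in place of hydrogen on a saturated chain carbon bound to two saturated chain carbons. In this assay compound 2 gives 8880 nM and compound 1 gives 8520 nM, a step of a 1.0-fold lower number from compound 2 to compound 1 (0.02 log units; within the scatter). Because a 1.0-fold lower number from compound 2 to compound 1 (0.02 log units; within the scatter) lies within the scatter, a similarly small step is expected a 1.0-fold higher number from compound 3 to compound 4 (0.01 log units; within the scatter). Compound 4 is estimated at 700 nM, likely between 350 nM and 1400 nM.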

Compound 4, concentration for 50% growth inhibition: 683 nM
For compound 4 the middle estimate is 1.0-fold (0.01 log units) above the measured one; measured number inside the range.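

In this assay, the added methyl makes no difference that can be told from scatter on this core, with a step of a 1.0-fold lower number from compound 3 to compound 4 (0.00 log units; within the scatter). The same kind of change on the other core gives a matching result: the same change on two cores in this assay, a 1.0-fold lower number (0.02 log units; within the scatter) from compound 2 to compound 1 and a 1.0-fold lower number (0.00 log units; within the scatter) from compound 3 to compound 4, 1.0-fold (0.01 log units) apart, within the scatter of two such steps. This shows that a single added methyl on these chains carries over between the two cores as a null result, but neither step moved beyond the scatter, so it does not show how a change with a real effect would transfer, and two pairs make no rule for the series.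

The compounds shown leave open whether a longer chain than the butyl of compound 4, or a chain carrying an amine or a carboxylic acid, would shift growth inhibition on either core.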